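This account rests on a few compounds, and the source may have more. Where it says the series, first, only, none or still open, it means among the compounds named here.

Among the measured compounds shown here, in a functional assay on A549 cells (Homo sapiens) for cytotoxicity, read by MTT assay, with a stated time of 72 h (a lower number here means a stronger inhibitor, a higher number a weaker inhibitor), compound 3 `COc1ccc(/C=C2\CCC/C(=C\c3cccc(Cl)c3)C2=O)cc1OC` gives 11000 nM, the only number so far. Compound 1 `COc1ccccc1/C=C1\CCC/C(=C\c2cccc(OC)c2OC)C1=O` gives > 20000 nM, which is a limit. Compound 2 `COc1cccc(/C=C2\CCC/C(=C\c3ccc(O)c(O)c3)C2=O)c1OC` gives > 20000 nM, also a limit. Compound 4 `COc1ccc(/C=C2\CCC/C(=C\c3cccc(O)c3)C2=O)cc1OC` carries hydroxy in place of chloro on an aromatic carbon, hydroxy in place of chloro on an aromatic carbon, meta to a large group. For the measured compounds named here, the only measured step, a step that the two limits leave unreadable from compound 1 to compound 2, introduces 3,4-dihydroxyphenyl at a different place and gives no size, so it sets no direction. With no readable step to draw on, the expected change is a 1.2-fold higher number from compound 3 to compound 4 (0.07 log units; within the scatter), not beyond the scatter. Compound 4 is estimated at 13000 nM, with an expected range from 5000 nM to 25000 nM.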

Compound 4, half-maximal inhibitory concentration: 4300 nM
Compound 4: middle estimate off by 3.0-fold (0.48 log units), on the high side; the measured number lies below the stated range.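

In this assay, among the compounds shown here, hydroxy in place of chloro on an aromatic carbon, meta to a large group, gives a 2.6-fold lower number from compound 3 to compound 4 (0.41 log units; beyond the scatter), the first readable step. This place on the ring therefore responds to a change of group, with 3-hydroxyphenyl giving the lower number of the pair. The reading rests on this single pair on the shared core.

From the compounds shown here alone, whether an amine or a carboxylic acid at the same place would follow hydroxy remains open. Other comparisons in the series stay unreadable: the limit of > 20000 nM in this assay, at which 2 of the 4 values shown sit.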